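Tert-Butyl in Place of Ethyl on the Shared Core

The source may report more compounds than this note shows. Statements on the series, on what has been measured and on what is new or still open speak of the compounds shown alone.

Compound 1 `Nc1nccnc1C(=O)Nc1ccncc1` gives 23000 nM in an assay for inhibition of protein kinase C iota type (Homo sapiens), read by mobility shift assay, with a stated time of 60 min; a higher number here means a weaker inhibitor, a lower number a stronger inhibitor.
Compound 2 `Nc1nccnc1C(=O)Nc1ccnc2[nH]ccc12` gives only a limit of this assay, > 384000 nM.
Compound 3 `CCc1cc(NC(=O)c2nccnc2N)ccn1` gives 19600 nM in this assay.

Compound 3 has the lowest of the two numbers, with compound 1 nearest, and the step of a 1.2-fold lower number from compound 1 to compound 3 (0.07 log units; within the scatter) lies within the scatter. Compound 4 `CC(C)(C)c1cc(NC(=O)c2nccnc2N)ccn1` differs from compound 3 by tert-butyl in place of ethyl on an aromatic carbon. Going by the values given here, the only measured step that bears on this change is a 1.2-fold lower number from compound 1 to compound 3 (0.07 log units; within the scatter), which shows that putting ethyl at this position did not move the number beyond the scatter. A further growth of the alkyl group there is therefore expected to give no step beyond the scatter in this assay, a 1.0-fold higher number from compound 3 to compound 4 (0.01 log units; within the scatter). Compound 4 is expected to give about 20000 nM, between 6000 nM and 70000 nM.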

Compound 4, half-maximal inhibitory concentration: 24000 nM
For compound 4 the middle estimate is 1.2-fold (0.08 log units) below the measured one; low and high end bracket the measured number.
By their numbers in this assay, from the lowest: compounds 3, 1 and 4 (each within the scatter of the next). At a limit, above all of these: compound 2.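

In this assay, replacing ethyl with tert-butyl gives a 1.2-fold higher number from compound 3 to compound 4 (0.09 log units; within the scatter), and the full replacement of hydrogen with tert-butyl gives a 1.0-fold higher number from compound 1 to compound 4 (0.02 log units; within the scatter). This aromatic carbon next to the ring nitrogen therefore carries hydrogen, ethyl or tert-butyl with every step within the scatter, now including the larger branched group. Nothing shown here bears on the reason for this. Still open, as far as these compounds go, is whether an amine or a carboxylic acid at this position would give a step beyond the scatter.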